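The compounds below may be only part of what the source reports. "The series", "measured", "known", "first", "only" and "open" are said of these compounds alone.

Measured so far in a physicochemical assay for solubility, using the shake flask method, in simulated intestinal fluid, measured as kinetic solubility, with a stated time of 20 h, at pH 6.5; on this read-out higher numbers stand for higher solubility and lower numbers for lower solubility:

Compound 1, `Fc1ccc(Nc2cc3[nH]c(-c4cccc(C(F)(F)F)c4)nc3cn2)nc1`, gives >= 50000 nM; this is a limit of the assay, not a number.
Compound 2, `Fc1ccc(-c2nc3cnc(Nc4cc(C(F)(F)F)ccn4)cc3[nH]2)cc1F`, gives >= 50000 nM; again a limit of the assay.
Compound 3, `Fc1ccc(Nc2cc3[nH]c(-c4ccc(F)c(F)c4)nc3cn2)nc1`, gives >= 50000 nM; again a limit of the assay.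

Where compound 1 stands is therefore only a boundary: the limit of >= 50000 nM in this assay, at which 3 of the 3 values shown sit. Among the measured compounds shown here, no real step between measured compounds can be read from this, since none of the three returned a number, and the only thing the three share is that each sits at that same boundary.

Compound 4, `O=C(O)c1ccnc(Nc2cc3[nH]c(-c4cccc(C(F)(F)F)c4)nc3cn2)c1`, is still to be measured in this assay. Relative to compound 1 the change is 4-carboxypyridin-2-yl in place of 5-fluoropyridin-2-yl on a nitrogen on an aromatic ring, in words 4-carboxypyridin-2-yl in place of 5-fluoropyridin-2-yl on a nitrogen on an aromatic ring.

With compound 1 already at the boundary, the step of a number no higher from compound 1 to compound 4 (the limit leaves the size open) is expected to show no change beyond the scatter, the assay most likely reporting the same limit again for compound 4. The estimate for compound 4 is 50000 nM, with a range from 15000 nM to 50000 nM.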

Compound 4, solubility: 60000 nM
Estimate against measurement, compound 4: 1.2-fold (0.08 log units) below, and the stated range ends below it.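

In this assay, among the compounds shown here, compound 1 gives >= 50000 nM, a limit of the assay and not a number, so no step to compound 4 can be read. The compounds shown leave open how 4-carboxypyridin-2-yl and 5-fluoropyridin-2-yl compare on this read-out.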